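A few compounds are considered here, and "the series" means these few. Any claim that something is new, unique, unknown or untested is made for them only; others in the source may bear on it.

Series notes. The shared core is carried by compound 1 `COC(=O)c1cc(-c2cccc(NC(=O)c3ccc(/C=C/C(=O)c4ccccc4)cc3)c2)on1`, compound 2 `COC(=O)c1cc(-c2cccc(NC(=O)c3ccc(/C=C/C(=O)c4cc(F)ccc4F)cc3)c2)on1`, compound 3 `COC(=O)c1cc(-c2cccc(NC(=O)c3ccc(/C=C/C(=O)c4ccc(C)cc4)cc3)c2)on1` and the not yet measured compound 4 `COC(=O)c1cc(-c2cccc(NC(=O)c3ccc(/C=C/C(=O)c4cccc(Cl)c4)cc3)c2)on1`. In an ADME assay on Vero cells (Chlorocebus sabaeus) for cytotoxicity, read by MTT assay, with a stated time of 72 h (on this read-out lower numbers stand for higher toxicity in this test and higher numbers for lower toxicity in this test), compound 1 gives only a limit, > 50 ug/mL. Compound 2 likewise gives only a limit in this assay, > 40 ug/mL. Compound 3 gives only a limit in this assay, > 80 ug/mL. Going by the values given here, compound 3 thus stands where every value so far sits, at a limit and not a number, so no order among the three compounds can be read. The change to compound 4 is 3-chlorophenyl in place of 4-methylphenyl on a carbonyl carbon. Among the compounds with values here, the steps that bear on it all alter the ring on that carbonyl carbon: a step that the two limits leave unreadable from compound 1 to compound 3, a step that the two limits leave unreadable from compound 2 to compound 3 and a step that the two limits leave unreadable from compound 1 to compound 2. Each is unreadable because the values at the limit of > 40 ug/mL in this assay, at which 1 of the 3 values shown sits, the limit of > 50 ug/mL in this assay, at which 1 of the 3 values shown sits, and the limit of > 80 ug/mL in this assay, at which 1 of the 3 values shown sits, are limits. In this assay no step beyond the scatter is therefore expected for compound 4, and the estimated step is an at least 1.1-fold lower number from compound 3 to compound 4 (0.05 log units; that floor lies within the scatter). Compound 4 is expected to reach a limit again in this assay. The estimate for compound 4 in this assay is 70 ug/mL, within 40 ug/mL to 120 ug/mL.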

Compound 4, half-maximal cytotoxic concentration: > 2.5 ug/mL
Compound 4: no number, only a limit (the forecaster's own chance of this, stated with the estimate: 85%); the middle value lies beyond the limit too.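

In this assay compound 4 gives > 2.5 ug/mL, a limit and not a number. Going by these compounds alone, compound 1, compound 2 and compound 3 also give only limits, so no step to compound 4 can be read. As far as these compounds go, whether changing the ring on the carbonyl carbon alters cytotoxicity at all remains open.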